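Replacing a Terminal Alkyne Hydrogen in an Agonist Series

The compounds below may be only part of what the source reports. "The series", "measured", "known", "first", "only" and "open" are said of these compounds alone.

Three compounds have been measured in an assay on HEK293 cells for agonist activity at Toll-like receptor 8 (Homo sapiens), read by spectrophotometry; a higher number here means that more compound is needed for the effect, a lower number that less compound is needed:

Compound 1 `CCCCNc1nc(N)nc(C)c1C#CCN1CCCCC1` gives 3790 nM.
Compound 2 `CCCC#Cc1c(C)nc(N)nc1NCCCC` gives 5000 nM.
Compound 3 `C#Cc1c(C)nc(N)nc1NCCCC` gives 4900 nM.

Among these three numbers compound 3 stands second highest. Its nearest neighbour is compound 2, and the gap between them, a 1.0-fold lower number from compound 2 to compound 3 (0.01 log units; within the scatter), is within the scatter. The furthest number belongs to compound 1, yet even there the step of a 1.3-fold higher number from compound 1 to compound 3 (0.11 log units; within the scatter) stays within the scatter, as does a 1.3-fold higher number from compound 1 to compound 2 (0.12 log units; within the scatter). The three values therefore cannot be ordered against one another.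

Compound 4 `CCCCNc1nc(N)nc(C)c1C#C[Si](C)(C)C` has not yet been measured. It differs from compound 3 in one place: a group of 4 heavy atoms (3 carbon, 1 silicon; no ring) in place of a hydrogen atom, on a triple-bonded carbon.

Within the data shown here, two measured steps touch the same position on the triple-bonded carbon. The exchange of propyl for hydrogen there gave a 1.0-fold lower number from compound 2 to compound 3 (0.01 log units; within the scatter), and the exchange of (piperidin-1-yl)methyl for hydrogen gave a 1.3-fold higher number from compound 1 to compound 3 (0.11 log units; within the scatter); neither left the scatter. On this basis no step beyond the scatter is expected in this assay from compound 3 to compound 4, and the estimated step is a 1.0-fold higher number from compound 3 to compound 4 (0.01 log units; within the scatter). Compound 4 is accordingly estimated at 5000 nM, within a range from 2000 nM to 12500 nM.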

Compound 4, half-maximal effective concentration: 9240 nM
Compound 4: the middle estimate sits 1.8-fold (0.27 log units) below what was measured; the range from low to high includes it.
By their numbers in this assay, from the lowest: compounds 1, 3, 2 and 4 (each within the scatter of the next, the first and the last beyond it).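

In this assay, among these compounds, the group of 4 heavy atoms (3 carbon, 1 silicon; no ring) on a triple-bonded carbon gives the first step at this position to pass beyond the scatter, a 2.4-fold higher number from compound 1 to compound 4 (0.39 log units; beyond the scatter), and that step is set against the (piperidin-1-yl)methyl group alone. Against the other two groups the same exchange does not leave the scatter, with a 1.9-fold higher number from compound 3 to compound 4 (0.28 log units; within the scatter) and a 1.8-fold higher number from compound 2 to compound 4 (0.27 log units; within the scatter), so hydrogen, the propyl-bearing chain and the silicon group cannot be told apart here, and only the two ends of the series separate. No measurement is available that would account for this one separated pair.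

The compounds shown leave open whether the silicon atom itself matters, and a tert-butyl group on the same triple-bonded carbon would test that directly. They also leave open whether a carboxylic acid, a phenyl ring or a longer chain carrying a primary amine at this position would move the number further in either direction, as all the groups seen so far span only a narrow range.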